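The source may hold more compounds than are shown below. What is called first, only, known or untested is meant among the compounds shown, and "the series" means these compounds.

In a functional assay on HCT-116 cells (Homo sapiens) for antiproliferative activity, read by sulforhodamine B assay, with a stated time of 72 h (on this read-out lower numbers stand for stronger inhibition and higher numbers for weaker inhibition), compound 1 (`Cn1cc(-c2ccc(=O)n(CCOc3ccnc4cc(OCCCCC(=O)NO)ccc34)n2)cn1`) gives > 10000 nM, which is a limit of the assay and not a number. Compound 2 (`Cn1cc(-c2ccc(=O)n(CCOc3ccnc4cc(OCc5ccc(C(=O)Nc6ccccc6N)cc5)ccc34)n2)cn1`), also bearing a 2-aminophenyl amide, gives 1800 nM in this assay. Compound 3 (`Cn1cc(-c2ccc(=O)n(CCOc3ccnc4cc(C(=O)Nc5ccccc5N)ccc34)n2)cn1`) differs from compound 1 by (2-aminophenyl)carbamoyl in place of 4-(hydroxycarbamoyl)butoxy on an aromatic carbon, with (2-aminophenyl)carbamoyl in place of 4-(hydroxycarbamoyl)butoxy on an aromatic carbon. Within the data shown here, the only number in hand, compound 2 at 1800 nM, points to an expected move toward stronger inhibition in this assay, of modest size. The estimated step is an at least 2.5-fold lower number from compound 1 to compound 3 (0.39 log units; beyond the scatter). Compound 3 is expected at 4000 nM, with an estimated range of 1200 nM to 10000 nM.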

Compound 3, half-maximal inhibitory concentration: > 10000 nM
Compound 3: no number, only a limit; the forecaster's own chance of this, stated with the estimate: 30%; at least 2.5-fold (0.39 log units) between middle value and limit.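

No step can be read from compound 1 to compound 3, as both values are limits and not numbers: the limit of > 10000 nM in this assay, at which 2 of the 3 values shown sit. Still open, from the compounds shown here alone, is whether 4-(hydroxycarbamoyl)butoxy or (2-aminophenyl)carbamoyl gives the stronger inhibition on the shared core.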